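The source may hold more compounds than are shown below. What is called first, only, known or untested is meant among the compounds shown, and "the series" means these compounds.

Of the compounds shown here, three that share one core have been measured in a functional assay on MDA-MB-435 cells (Homo sapiens) for antiproliferative activity, read by MTT assay, with a stated time of 5 days; a higher number here means a weaker inhibitor, a lower number a stronger inhibitor. Compound 1 `COc1cc[nH]c1/C=C1\C(=O)Nc2ccc([N+](=O)[O-])c(N[C@H]3CC[C@H](O)CC3)c21`, which carries (4-hydroxycyclohexyl)amino, gives 8550 nM. Compound 2 `COc1cc[nH]c1/C=C1\C(=O)Nc2ccc([N+](=O)[O-])c(N3CCC(O)CC3)c21`, which carries 4-hydroxypiperidin-1-yl, gives 46 nM. Compound 3 `COc1cc[nH]c1/C=C1\C(=O)Nc2ccc([N+](=O)[O-])c(N3CC[C@@H](O)C3)c21`, which carries 3-hydroxypyrrolidin-1-yl, gives 88 nM. That puts compound 3 level with compound 2 and far from compound 1, since the measured gap is a 1.9-fold higher number from compound 2 to compound 3 (0.28 log units; within the scatter).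

The next structure is compound 4 `COc1cc[nH]c1/C=C1\C(=O)Nc2ccc([N+](=O)[O-])c(N[C@H]3CC[C@H](N)C3)c21`, and the change is (3-aminocyclopentyl)amino in place of 3-hydroxypyrrolidin-1-yl on an aromatic carbon. The most relevant measurements are the two steps away from the (4-hydroxycyclohexyl)amino group of compound 1: a 190-fold lower number from compound 1 to compound 2 (2.27 log units; beyond the scatter) and a 97-fold lower number from compound 1 to compound 3 (1.99 log units; beyond the scatter). Compound 4 again has an amino group joining a carbon-only ring to the core, so those two steps, read backwards, suggest a large rise in the number from compound 3. However, no measured compound carries an amino group on that ring, and the ring here is five-membered, so the full size of those steps is not assumed and the uncertainty is wide. The expected change is a 14-fold higher number from compound 3 to compound 4 (1.13 log units; beyond the scatter). The estimate for compound 4 is 1200 nM, with an expected range from 150 nM to 9000 nM.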

Compound 4, half-maximal inhibitory concentration: 61 nM
Beside the measured number, compound 4's estimate is 20-fold (1.29 log units) above it, and the stated range ends above it.
By their numbers in this assay, from the lowest: compounds 2, 4 and 3 (each within the scatter of the next); then compound 1.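

In this assay, (3-aminocyclopentyl)amino on this aromatic carbon, ortho to a nitro group, performs like the two groups attached through a ring nitrogen: the results are a 1.4-fold lower number from compound 3 to compound 4 (0.16 log units; within the scatter) and a 1.3-fold higher number from compound 2 to compound 4 (0.12 log units; within the scatter), both within the scatter. Going by these compounds alone, compound 4 nevertheless shares with compound 1 an amino nitrogen carrying a carbon-only ring, and the step between them is large (a 140-fold lower number from compound 1 to compound 4 (2.15 log units; beyond the scatter)), so this kind of link can accompany a low number, which the earlier compounds could not show because compound 1 was their only example. The weak result for compound 1 therefore cannot be assigned to the amino link alone.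

The data shown include no independent evidence that explains this difference. The step from compound 1 to compound 4 changes the ring size and replaces a hydroxyl with an amine at the same time, leaving open which change matters, or whether both do; (4-aminocyclohexyl)amino and (3-hydroxycyclopentyl)amino would each separate the two changes.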